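The source may report more compounds than this note shows. Statements on the series, on what has been measured and on what is new or still open speak of the compounds shown alone.

Measured so far in an assay on CHO cells for antagonist activity at transient receptor potential cation channel subfamily V member 1 (Homo sapiens), read by FLIPR; on this read-out lower numbers stand for stronger inhibition and higher numbers for weaker inhibition:

Compound 1 `CCCCSc1cc(C(F)(F)F)ccc1CNC(=O)C(C)c1ccc(NS(C)(=O)=O)c(F)c1`: 1.9 nM
Compound 2 `CC(C(=O)NCc1ccc(C(F)(F)F)cc1SCc1ccccc1)c1ccc(NS(C)(=O)=O)c(F)c1`: 0.5 nM

Compound 2 holds the lowest of the two numbers in this assay; its nearest neighbour is compound 1, and the step of a 3.8-fold lower number from compound 1 to compound 2 (0.58 log units; beyond the scatter) stands beyond the scatter. For the measured compounds named here, that step is the only one measured on the group bound to sulfur, and it shows a modest gain when an aromatic ring replaces a chain at this place.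

Compound 3 `CC(C(=O)NCc1ccc(C(F)(F)F)cc1SCc1ccco1)c1ccc(NS(C)(=O)=O)c(F)c1` is not yet measured. It differs from compound 2 by furan-2-yl in place of phenyl on a saturated chain carbon bound to a sulfur. Going by the values given here, no measured step bears directly on swapping one aromatic ring for another here; the one measured step from compound 1 to compound 2 says only that an aromatic ring at this place is tolerated well. An aromatic ring remains in compound 3, so the expectation is a step of a 1.6-fold higher number from compound 2 to compound 3 (0.20 log units; within the scatter) that stays within the scatter. For compound 3 in this assay the estimate is 0.8 nM, with a range from 0.3 nM to 2.5 nM.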

Compound 3, inhibition constant: 3.2 nM
Compound 3: middle estimate off by 4.0-fold (0.60 log units), on the low side, outside the stated range (above it).
By their numbers in this assay, from the lowest: compound 2; then compounds 1 and 3 (each within the scatter of the next).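

In this assay the place on a saturated chain carbon bound to a sulfur proves sensitive to which aromatic ring it carries: furan-2-yl in place of phenyl gives a 6.4-fold higher number from compound 2 to compound 3 (0.81 log units; beyond the scatter) and an aromatic ring as such is therefore not enough to keep the result of compound 2. Furan-2-yl in place of propyl gives a 1.7-fold higher number from compound 1 to compound 3 (0.23 log units; within the scatter) so compound 1 and compound 3 cannot be told apart, and among the three groups shown only phenyl stands beyond the scatter from the others. Nothing at hand accounts for the gap between the phenyl and furan-2-yl rings.

Ring size and the ring oxygen change together in this one swap, so the compounds shown leave open which of the two goes with the step; thiophen-2-yl at this place would separate them. Also open, on these data alone, is whether a ring is needed to be aromatic at all, a question that cyclohexyl would address.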